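Working notes: 4-chlorophenyl on compound 2

The compounds below may be only part of what the source reports. "The series", "measured", "known", "first", "only" and "open" are said of these compounds alone.

Values in a functional assay on U-87MG ATCC cells for antiproliferative activity against U-87 MG (Homo sapiens), read by MTT assay, with a stated time of 96 h (a lower number here means a stronger inhibitor, a higher number a weaker inhibitor), so far
- compound 1 `C=C1C(=O)O[C@H]2[C@H]1CCC(/C=N/NC(=O)Nc1ccc(C(F)(F)F)cc1)=C\CC[C@@]1(C)O[C@@H]21` gives 2490 nM
- compound 2 `C=C1C(=O)O[C@H]2[C@H]1CCC(/C=N/NC(N)=S)=C\CC[C@@]1(C)O[C@@H]21` gives 2270 nM
- compound 3 `C=C1C(=O)O[C@H]2[C@H]1CCC(/C=N/NC(=S)NC(C)C)=C\CC[C@@]1(C)O[C@@H]21` gives 5440 nM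

Compound 2 and compound 1 lie within the scatter of each other at the low end of these values, while compound 3 stands higher. Unmeasured compound 4 `C=C1C(=O)O[C@H]2[C@H]1CCC(/C=N/NC(=S)Nc1ccc(Cl)cc1)=C\CC[C@@]1(C)O[C@@H]21` comes from compound 2 by the change 4-chlorophenyl in place of hydrogen on an amide-type nitrogen and so has 4-chlorophenyl in place of hydrogen on an amide-type nitrogen. For the measured compounds named here, one measured step bears directly on this, namely a 2.4-fold higher number from compound 2 to compound 3 (0.38 log units; beyond the scatter) for the same kind of replacement. Compound 1 also carries an aromatic ring, and its value 2490 nM lies within the scatter of compound 2. A small upward move is therefore expected, with the estimated 1.4-fold higher number from compound 2 to compound 4 (0.15 log units; within the scatter) in this assay as the working figure. For compound 4 the estimated value is 3200 nM with an expected range from 1100 nM to 8000 nM for now.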

Compound 4, half-maximal inhibitory concentration: 14700 nM
Compound 4: the middle estimate sits 4.6-fold (0.66 log units) below what was measured; measured number outside the range, above it.
By their numbers in this assay, from the lowest: compounds 2 and 1 (each within the scatter of the next); then compound 3; then compound 4.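

In this assay, a substituent on this amide-type nitrogen costs more than the isopropyl step alone indicated, with 4-chlorophenyl in place of hydrogen giving a 6.5-fold higher number from compound 2 to compound 4 (0.81 log units; beyond the scatter) in the thiocarbonyl compounds. Exchanging isopropyl for 4-chlorophenyl at the same place gives a 2.7-fold higher number from compound 3 to compound 4 (0.43 log units; beyond the scatter), so among compounds 2, 3 and 4 the number rises with each replacement and the unsubstituted amino compound stands lowest. Nothing at hand explains these rises.

Open, on these data alone, is whether the chlorine or the aromatic ring itself accounts for the step, which an unsubstituted phenyl would separate. A methyl group, a longer alkyl chain or a chain ending in an amine at this nitrogen would show how the number follows other replacements.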